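One Ring Cap Exchanged, Maximal Response Estimated

The compounds below may be only part of what the source reports. "The series", "measured", "known", "first", "only" and "open" are said of these compounds alone.

Of the compounds shown here, three share a core and have been tested in a functional assay on CHO-K1 cells for agonist activity at Glucose-dependent insulinotropic receptor (Mus musculus), read by HTRF and cAMP accumulation, with a stated time of 30 min; on this read-out higher numbers stand for larger maximal responses and lower numbers for smaller maximal responses. Compound 1 `CC(C)(C)OC(=O)N1CCC(CCCNc2ccc3c(c2)NNS3(=O)=O)CC1` gives 95%, compound 2 `CC(C)(C)OC(=O)N1CCC(CCCNc2ccc3c(c2)CCC3=O)CC1` gives 105%, and compound 3 `CCc1cnc(N2CCC(CCCNc3ccc4c(c3)OCC4=O)CC2)nc1` gives 98%. Compound 3 stands second highest of the three, yet both other values lie within the usual scatter of it, so none of the three can be said to differ from another. Compound 4 `CC(C)c1nsc(N2CCC(CCCNc3ccc4c(c3)OCC4=O)CC2)n1` has not been measured. It differs from compound 3 in one place: 3-isopropyl-1,2,4-thiadiazol-5-yl in place of 5-ethylpyrimidin-2-yl on an amine nitrogen in a ring. Within the data shown here, no measured pair shows the effect of such a swap, and the three known values sit close together, so no step beyond the scatter is expected in this assay in either direction. The step expected from this change is no change at the digits printed from compound 3 to compound 4 (within the scatter). Compound 4 is therefore estimated to reach 98%, within 85% to 110%.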

Compound 4, largest response reached (Emax), in percent of the reference or control that the assay uses: 93%
Compound 4: middle estimate off by 5 percentage points, on the high side; low and high end bracket the measured number.
By their numbers in this assay, from the lowest: compounds 4, 1, 3 and 2 (each within the scatter of the next, the first and the last beyond it).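

Among these compounds, this is the first pair that isolates a change on the amine nitrogen in a ring: 3-isopropyl-1,2,4-thiadiazol-5-yl in place of 5-ethylpyrimidin-2-yl gives a number 5 percentage points lower from compound 3 to compound 4 (within the scatter) in this assay. At this position, then, a six-membered aromatic ring with 2 hetero atoms can be exchanged for a five-membered one with 3 hetero atoms, including a sulfur, without a step beyond the scatter. No measurement here offers an explanation for this result. Still open, from the compounds shown here alone, is whether a phenyl ring or a carboxylic acid in this place would give a similar maximal response. A single pair also cannot show whether other thiadiazole substituents, such as a methyl group, behave alike.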